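Two styrylsulfonamides and an untested acid analogue

A few compounds are considered here, and "the series" means these few. Any claim that something is new, unique, unknown or untested is made for them only; others in the source may bear on it.

Compound 1 `COc1ccc(NS(=O)(=O)/C=C/c2c(F)c(F)c(F)c(F)c2F)cc1` gives 5000 nM in a functional assay on K562 cells (Homo sapiens) for cytotoxicity, read by trypan blue exclusion, with a stated time of 96 h; on this read-out higher numbers stand for weaker inhibition and lower numbers for stronger inhibition.
Compound 2 `COC(=O)C(Nc1cc(NS(=O)(=O)/C=C/c2c(OC)cc(OC)cc2OC)ccc1OC)c1ccccc1` gives 2500 nM in this assay.

Of the two numbers in hand, compound 2 holds the lower one, but its nearest neighbour is compound 1, and the gap between the two lies within the usual scatter, so the two cannot be ranked against each other. Compound 3 `COc1cc(OC)c(/C=C/S(=O)(=O)Nc2ccc(OC)c(NC(C(=O)O)c3ccc(Cl)cc3)c2)c(OC)c1` has not yet been tested in this assay. It differs from compound 2 in one place: carboxy(4-chlorophenyl)methyl in place of methoxycarbonyl)(benzyl on a nitrogen on an aromatic ring. Among the compounds with values here, no step between two measured compounds that share this kind of change is available, so there is nothing to measure the change against. The expectation, then, is a step of a 1.2-fold higher number from compound 2 to compound 3 (0.08 log units; within the scatter) from compound 2, that is, no step beyond the scatter in either direction. Compound 3 is expected to give about 3000 nM in this assay, with a likely range from 1000 nM to 10000 nM.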

Compound 3, half-maximal inhibitory concentration: 15 nM
Estimate against measurement, compound 3: 200-fold (2.30 log units) above, outside the stated range (below it).
By their numbers in this assay, from the lowest: compound 3; then compounds 2 and 1 (each within the scatter of the next).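

The nitrogen on an aromatic ring proves to be a place where this assay responds strongly, with a 170-fold lower number from compound 2 to compound 3 (2.22 log units; beyond the scatter) on exchanging methoxycarbonyl)(benzyl for carboxy(4-chlorophenyl)methyl, two groups of equal heavy-atom count. This one step changes two things at once, a methyl ester giving way to a carboxylic acid and a chlorine appearing on the phenyl ring, so it can be read only for the two changes together. Nothing at hand accounts for the size of this step.

The compounds shown leave open which of the two changes carries the step, a question that carboxy(phenyl)methyl, without the chlorine, and the methyl ester of carboxy(4-chlorophenyl)methyl would separate. Also open, as far as these compounds go, is whether a bromine in place of the chlorine, or a primary amide in place of the carboxylic acid, would keep so low a number.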